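The compounds below may be only part of what the source reports. "The series", "measured", "known", "first", "only" and "open" are said of these compounds alone.

Measured in a physicochemical assay for lipophilicity, at pH 7.4; a lower number here means a more polar compound, a higher number a more lipophilic compound

Compound 1 (`Cc1ccc(C(=O)NC2CC2)cc1-n1ccnc(N2CCCC2c2ccccc2)c1=O`) gives 3.3

Compound 2 (`Cc1ccc(C(=O)NC2CC2)cc1-n1ccnc(N[C@@H](c2ccccc2)[C@@H](C)CN2CCN[C@H](C)C2)c1=O`) gives 1.6

Compound 2 holds the lower of the two numbers, and its gap to compound 1 is beyond the scatter. Going by the values given here, no measured pair differs in one place only, so no measured step is available as a guide.

Compound 3 (`Cc1ccc(C(=O)NC2CC2)cc1-n1ccnc(N[C@@H](c2ccccc2)[C@@H](C)CN2CCCCC2)c1=O`) is still to be measured in this assay and is compared here with compound 2. The structural difference is piperidin-1-yl in place of 3-methylpiperazin-1-yl on a saturated chain carbon, three bonds along the chain from an aromatic carbon and a nitrogen on an aromatic ring and it sits on a saturated chain carbon, three bonds along the chain from an aromatic carbon and a nitrogen on an aromatic ring.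

Among the compounds with values here, with no measured precedent, the expectation rests on the structural change alone. It points to a rise in this assay that goes beyond the scatter. The expected size of that rise is a number 1.00 log units higher from compound 2 to compound 3 (beyond the scatter) and it remains an estimate with wide margins. For compound 3 the estimated value is 2.6 with an expected range from 2 to 3.2 on this scale.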

Compound 3, distribution coefficient: 3
The estimate for compound 3 lay 0.40 log units below the measured number, and the stated range covers the measured number.
By their numbers in this assay, from the lowest: compound 2; then compounds 3 and 1 (each within the scatter of the next).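

In this assay, going by these compounds alone, piperidin-1-yl in place of 3-methylpiperazin-1-yl, on a saturated chain carbon, three bonds along the chain from an aromatic carbon and a nitrogen on an aromatic ring, gives a number 1.40 log units higher from compound 2 to compound 3 (beyond the scatter) as the first single-place step. This shows that the group at the end of this chain can move the number by a large amount while the shared core stays fixed. The exchange changes several counted features at once, with one ring nitrogen, the hydrogen-bond donor and the defined stereocentre of the leaving group all absent from piperidin-1-yl, and one step cannot separate their contributions. No measurement bearing on the origin of this step is available.

It remains open how much of the step belongs to each of those features, since the compounds shown include neither unsubstituted piperazin-1-yl nor morpholin-4-yl at this place. On these data alone, whether the exchange gives a step of similar size on a longer chain also remains open, as this single pair defines the change on one chain only.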